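Shifting the methoxy on the benzyl arm: compound 3 to 4

A few compounds are considered here, and "the series" means these few. Any claim that something is new, unique, unknown or untested is made for them only; others in the source may bear on it.

Compound 3 `COc1cccc(CNCCCNS(=O)(=O)c2cc(C(F)(F)F)cc(C(F)(F)F)c2)c1` holds the lowest number of the three measured in a functional assay on A2780 cells (Homo sapiens) for inhibition, read by MTT assay, with a stated time of 72 h (a lower number here means a stronger inhibitor of growth, a higher number a weaker inhibitor of growth), giving 1600 nM. Compound 2 `CC(C)(C)c1ccc(CNCCCNS(=O)(=O)c2cc(C(F)(F)F)cc(C(F)(F)F)c2)cc1` gives 2900 nM and compound 1 `COc1ccc(CNCCCNS(=O)(=O)c2cc(C(F)(F)F)cc(C(F)(F)F)c2)cc1OC` gives 3800 nM. The gaps are a 1.8-fold lower number from compound 2 to compound 3 (0.26 log units; within the scatter), within the scatter, and a 2.4-fold lower number from compound 1 to compound 3 (0.38 log units; beyond the scatter), beyond it. Compound 4 `COc1ccc(CNCCCNS(=O)(=O)c2cc(C(F)(F)F)cc(C(F)(F)F)c2)cc1` differs from compound 3 by 4-methoxyphenyl in place of 3-methoxyphenyl on a saturated chain carbon bound to an amine nitrogen. The closest guide is the removal of one methoxy from the 3,4-dimethoxyphenyl of compound 1, which gave only a modest drop; the benzyl swaps a 1.3-fold lower number from compound 1 to compound 2 (0.12 log units; within the scatter) also moved little. A single methoxy at the other position is therefore not expected to beat compound 3. Compound 4 is expected to give 2400 nM (range 1200 nM to 5000 nM), a step of a 1.5-fold higher number from compound 3 to compound 4 (0.18 log units; within the scatter) expected within the scatter.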

Compound 4, concentration for 50% growth inhibition: 1700 nM
Compound 4: the middle estimate sits 1.4-fold (0.15 log units) above what was measured; measured number inside the range.
By their numbers in this assay, from the lowest: compounds 3, 4, 2 and 1 (each within the scatter of the next, the first and the last beyond it).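

In this assay, moving the methoxy gives a 1.1-fold higher number from compound 3 to compound 4 (0.03 log units; within the scatter), so on this arm the 3-methoxyphenyl and 4-methoxyphenyl groups are not separated. Methoxy in place of tert-butyl gives a 1.7-fold lower number from compound 2 to compound 4 (0.23 log units; within the scatter), also within the scatter, while hydrogen in place of methoxy gives a 2.2-fold lower number from compound 1 to compound 4 (0.35 log units; beyond the scatter), so a single methoxy at either position stands apart from the 3,4-dimethoxyphenyl arm, as in a 2.4-fold lower number from compound 1 to compound 3 (0.38 log units; beyond the scatter). Nothing available explains these steps.

Open, as far as these compounds go, is whether a hydroxy group or a chlorine on the aromatic carbon carrying the methoxy would shift the number beyond the scatter. From the compounds shown here alone, a longer chain in the shared core is equally open.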